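This account rests on a few compounds, and the source may have more. Where it says the series, first, only, none or still open, it means among the compounds named here.

Compound 1 `COc1ccc(/C=C/c2cc(OC)cc(OC)c2/C=C/C(=O)c2cccc(Br)c2)cc1` was tested in a functional assay on B16-F10 cells (Mus musculus) for antiproliferative activity, read by MTT assay, with a stated time of 48 h (a higher number here means a weaker inhibitor, a lower number a stronger inhibitor), and gave 5.1 ug/mL. Two close relatives share its core. Compound 2 `COc1ccc(/C=C/c2cc(OC)cc(OC)c2/C=C/C(=O)c2ccc(F)cc2)cc1` gave 5.3 ug/mL in this assay, and compound 3 `COc1ccc(/C=C/c2cc(OC)cc(OC)c2/C=C/C(=O)c2ccccc2)cc1` gave 3.7 ug/mL. The three numbers lie within the usual scatter of one another: the step of a 1.0-fold higher number from compound 1 to compound 2 (0.02 log units; within the scatter) and the step of a 1.4-fold lower number from compound 1 to compound 3 (0.14 log units; within the scatter) both fall inside it, as does the step of a 1.4-fold lower number from compound 2 to compound 3 (0.16 log units; within the scatter). Compound 1 therefore sits in the middle of a tight group, with no relative clearly apart from it.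

Compound 4 `COc1ccc(/C=C/c2cc(OC)cc(OC)c2/C=C/C(=O)c2ccc(-c3ccccc3)cc2)cc1` has not yet been tested. Relative to compound 1 the change is 4-phenylphenyl in place of 3-bromophenyl on a carbonyl carbon. Among the compounds with values here, the steps that bear on it are those that also alter the ring on the carbonyl carbon: a 1.0-fold higher number from compound 1 to compound 2 (0.02 log units; within the scatter) swaps one substituted ring for another, and a 1.4-fold lower number from compound 1 to compound 3 (0.14 log units; within the scatter) removes the bromine, and neither moved the number beyond the scatter. Within the data shown here, no measured compound carries an added ring, so the effect of the extra phenyl is not known from these data. On that basis the expected step is a 1.0-fold lower number from compound 1 to compound 4 (0.01 log units; within the scatter), with no direction favoured beyond the scatter. Compound 4 is thus estimated at 5 ug/mL in this assay, with a likely range from 2 ug/mL to 13 ug/mL.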

Compound 4, half-maximal inhibitory concentration: 10.6 ug/mL
Compound 4: middle estimate off by 2.1-fold (0.33 log units), on the low side, within the range that was stated.
By their numbers in this assay, from the lowest: compounds 3, 1, 2 and 4 (each within the scatter of the next, the first and the last beyond it).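

In this assay, the ring on the carbonyl carbon now shows its first change beyond the scatter: a 2.9-fold higher number from compound 3 to compound 4 (0.46 log units; beyond the scatter) comes from phenyl in place of hydrogen, and a 2.1-fold higher number from compound 1 to compound 4 (0.32 log units; beyond the scatter) comes from 4-phenylphenyl in place of 3-bromophenyl, so compound 4 is a weaker inhibitor than these two relatives, though both steps are only modest. The comparison with the fluoro compound is less firm, as a 2.0-fold higher number from compound 2 to compound 4 (0.30 log units; within the scatter) stays within the scatter, and the second ring is therefore not clearly set apart from a fluoro group at that carbon. Nothing measured here gives a reason for the shift.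

Only 4-phenylphenyl carries an added ring among these compounds, so a single example stands for that whole kind of change. From the compounds shown here alone, it remains open whether a pyridine ring in place of the added phenyl, or an amine or a carboxylic acid placed on that phenyl, would bring the number back towards that of compound 3 or move it further away.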